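Butyl to Cyclohexyl on the Amide Nitrogen of a Hydroxamate

The source may hold more compounds than are shown below. What is called first, only, known or untested is meant among the compounds shown, and "the series" means these compounds.

Compound 1, `CCCCNC(=O)CN(CCCCCC(=O)NO)C(=O)c1ccc(N(C)C)cc1`: 3190 nM
Compound 2, `O=C(CCCCCN(C(=O)c1ccccc1)C1(C(=O)NC2CCCCC2)CCCCC1)NO`: 50500 nM

In a functional assay on A2780cisR cells (Homo sapiens) for cytotoxicity, read by MTT assay, with a stated time of 72 h (a lower number here means a stronger inhibitor, a higher number a weaker inhibitor), compound 1 gives 3190 nM, the lower of the two measured numbers. Compound 2 gives 50500 nM, and the gap to compound 1 lies beyond the usual scatter. Compound 3, `CN(C)c1ccc(C(=O)N(CCCCCC(=O)NO)CC(=O)NC2CCCCC2)cc1`, is not yet measured; it differs from compound 1 in a single place: cyclohexyl in place of butyl on an amide-type nitrogen. Going by the values given here, no measured pair shows this change, so the expectation rests on compound 1 alone. The step of a 1.2-fold lower number from compound 1 to compound 3 (0.09 log units; within the scatter) is expected to be small, within the usual scatter, with no clear direction. Compound 3 is estimated at 2600 nM, ranging from 1000 nM to 7000 nM.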

Compound 3, half-maximal inhibitory concentration: 3310 nM
Compound 3: middle estimate off by 1.3-fold (0.10 log units), on the low side; the range from low to high includes it.
By their numbers in this assay, from the lowest: compounds 1 and 3 (each within the scatter of the next); then compound 2.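

Placing cyclohexyl in place of butyl on the amide-type nitrogen gives a 1.0-fold higher number from compound 1 to compound 3 (0.02 log units; within the scatter) in this assay, so this position accepts a ring as well as an open chain on the core of compound 1. Compound 1 and compound 3 cannot be told apart here. Nothing available explains why the two groups read alike.

Going by these compounds, whether an amine, a carboxylic acid or a longer chain would read alike at this position stays open. So does whether butyl and cyclohexyl would also match on the core of compound 2.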